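The compounds below may be only part of what the source reports. "The series", "measured", "known", "first", "only" and "open" are said of these compounds alone.

Measured compounds so far:

compound 1 `C[C@@H]1CN(c2cccc3c2C[C@H](CN(C)[C@H]2CCCc4cccnc42)NC3)C[C@H](C)N1` — 61 nM
compound 2 `CN(C[C@H]1Cc2c(cccc2N2CCN(C3CC3)CC2)CN1)[C@H]1CCCc2cccnc21` — 23.5 nM

In a functional assay on CCRF-CEM cells for antagonist activity at C-X-C chemokine receptor type 4 (Homo sapiens), read by calcium flux, with stated times of 25 min and 90 s (a lower number here means a stronger inhibitor, a higher number a weaker inhibitor), compound 2 gives 23.5 nM, the lowest of the two numbers; the nearest is compound 1, whose value is 61 nM. Within the data shown here, the only measured step is a 2.6-fold lower number from compound 1 to compound 2 (0.41 log units; beyond the scatter), a modest improvement obtained by exchanging a dimethyl-bearing piperazine for a cyclopropyl-bearing one on an aromatic carbon of the shared core.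

Compound 3 `CN(C[C@H]1Cc2c(cccc2N2CCNC(C)(C)C2)CN1)[C@H]1CCCc2cccnc21` has not been measured. It differs from compound 2 by 3,3-dimethylpiperazin-1-yl in place of 4-cyclopropylpiperazin-1-yl on an aromatic carbon. Among the measured compounds shown here, this is close to a reversal of the one measured step, since a dimethyl-bearing piperazine with a free hydrogen-bond donor returns, though the two methyl groups now sit on one carbon rather than on two, so no measured pair matches it exactly.

Because the step of a 2.6-fold lower number from compound 1 to compound 2 (0.41 log units; beyond the scatter) was modest and this change largely undoes it, compound 3 is expected to give a modestly higher number than compound 2, roughly back toward compound 1, a 1.9-fold higher number from compound 2 to compound 3 (0.28 log units; within the scatter). The estimated value for compound 3 in this assay is 45 nM, with a likely range from 18 nM to 110 nM.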

Compound 3, half-maximal inhibitory concentration: 33.9 nM
For compound 3 the middle estimate is 1.3-fold (0.12 log units) above the measured one; the measured number falls inside the stated range.
By their numbers in this assay, from the lowest: compounds 2, 3 and 1 (each within the scatter of the next, the first and the last beyond it).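

In this assay, exchanging 4-cyclopropylpiperazin-1-yl for 3,3-dimethylpiperazin-1-yl on this aromatic carbon gives a 1.4-fold higher number from compound 2 to compound 3 (0.16 log units; within the scatter), so the assay cannot tell these two groups apart, even though the entering group has a hydrogen-bond donor and the leaving group has none. Compound 3 also cannot be separated from compound 1, since the change from 3,5-dimethylpiperazin-1-yl to 3,3-dimethylpiperazin-1-yl gives a 1.8-fold lower number from compound 1 to compound 3 (0.26 log units; within the scatter), whereas the direct comparison of the other two compounds gives a 2.6-fold lower number from compound 1 to compound 2 (0.41 log units; beyond the scatter) and so stays beyond the scatter. The data give no measured explanation for any of these small differences.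

As far as these compounds go, all three compounds carry a substituted piperazine at this position, so it remains open how a morpholine or a simple dimethylamino group on the same aromatic carbon would behave. Also unresolved is how far the piperazine itself can be varied, for example with an unsubstituted piperazine or with a longer chain such as n-butyl on its outer nitrogen in place of cyclopropyl.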